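A few compounds are considered here, and "the series" means these few. Any claim that something is new, unique, unknown or untested is made for them only; others in the source may bear on it.

Working notes on the series. In a functional assay on A549 cells (Homo sapiens) for cytotoxicity, read by MTT assay, with a stated time of 48 h (a higher number here means a weaker inhibitor, a lower number a stronger inhibitor), compound 1 `CCOC(=O)c1c(-c2cc3ccccc3oc2=O)nn(-c2ccccc2)c1C(=O)OCC` gives 100000 nM. Compound 2 `CCOC(=O)c1c(-c2cc3ccccc3oc2=O)nn(-c2cccc(C)c2)c1C(=O)OCC` gives 52000 nM in this assay, and compound 3 `CCOC(=O)c1c(-c2cc3ccccc3oc2=O)nn(-c2ccc(C)c(C)c2)c1C(=O)OCC` gives 52000 nM. The step of a 1.9-fold lower number from compound 1 to compound 2 (0.28 log units; within the scatter) and the step of a 1.9-fold lower number from compound 1 to compound 3 (0.28 log units; within the scatter) both stay within the scatter, as does no change at the digits printed from compound 2 to compound 3 (within the scatter). Within the data shown here, compound 3 thus sits at the same number as compound 2 at the digits given, and its gap to compound 1 is within the scatter; no compound of the three can be set apart from the others on these numbers.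

Compound 4 `CCOC(=O)c1c(-c2cc3ccccc3oc2=O)nn(-c2ccc(OC)cc2)c1C(=O)OCC` is not yet measured. Its change from compound 3 is 4-methoxyphenyl in place of 3,4-dimethylphenyl on an aromatic nitrogen. Among the measured compounds shown here, no measured step involves a methoxy group on this aryl ring; what bears on the change is that every variation of the aryl group on the aromatic nitrogen so far, the steps of a 1.9-fold lower number from compound 1 to compound 2 (0.28 log units; within the scatter) and no change at the digits printed from compound 2 to compound 3 (within the scatter), has stayed within the scatter. The expectation is therefore no step beyond the scatter in this assay, with a 1.2-fold higher number from compound 3 to compound 4 (0.06 log units; within the scatter) as the estimated step. Compound 4 is expected at 60000 nM, with the range 25000 nM to 130000 nM.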

Compound 4, half-maximal inhibitory concentration: 86000 nM
Estimate against measurement, compound 4: 1.4-fold (0.16 log units) below; low and high end bracket the measured number.
By their numbers in this assay, from the lowest: compounds 2, 3, 4 and 1 (each within the scatter of the next).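

In this assay, the 4-methoxyphenyl group brings the first oxygen and the first hydrogen-bond acceptor to the aryl group on the aromatic nitrogen, yet the comparison with the dimethylated aryl group reads a 1.7-fold higher number from compound 3 to compound 4 (0.22 log units; within the scatter) and the comparison with the monomethylated one reads a 1.7-fold higher number from compound 2 to compound 4 (0.22 log units; within the scatter) in this series. Against the unsubstituted phenyl group, the reading is a 1.2-fold lower number from compound 1 to compound 4 (0.07 log units; within the scatter) and so adds no separation either: at this position, the methoxy group can no more be told apart from hydrogen than the methyl groups can, and all steps among the four compounds remain within the scatter. No measurement here bears on the cause of these numbers.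

As far as these compounds go, it remains open whether a carboxylic acid, an amine or a longer alkoxy chain on this aryl ring would give a step beyond the scatter, since only methyl and methoxy groups have been compared there. The compounds shown also leave open what a carboxylic acid or an amide in place of either ethoxycarbonyl group would do, as both groups stay the same throughout.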